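This account rests on a few compounds, and the source may have more. Where it says the series, first, only, none or still open, it means among the compounds named here.

Measured in a functional assay on DU-145 cells (Homo sapiens) for inhibition, read by CCK-8 assay, with a stated time of 72 h; a lower number here means a stronger inhibitor, a higher number a weaker inhibitor:

- Compound 1 `O=C(/C=C/c1cccnc1)NCCCc1cccc(S(=O)(=O)Nc2ccccc2)c1`: 165 nM
- Compound 2 `O=C(/C=C/c1cccnc1)NCCCCCc1cccc(S(=O)(=O)Nc2ccccc2)c1`: 140 nM
- Compound 3 `Cc1ccc(NS(=O)(=O)c2cccc(CCCCCCNC(=O)/C=C/c3cccnc3)c2)cc1`: 34.4 nM

Compound 3 gives the lowest number of the three, and its gaps to compound 1 and compound 2 both lie beyond the usual scatter. Compound 4 `O=C(/C=C/c1cccnc1)NCCCCCCc1cccc(S(=O)(=O)Nc2ccc(F)c(Cl)c2)c1` has not yet been measured in this assay. It carries 3-chloro-4-fluorophenyl in place of 4-methylphenyl on a sulfonamide nitrogen. Going by the values given here, no measured pair of compounds shows this change on its own, so the starting point is the value of compound 3 at 34.4 nM, with no step beyond the scatter expected in either direction. The expected change is a 1.0-fold higher number from compound 3 to compound 4 (0.01 log units; within the scatter). For compound 4 the estimated value is 35 nM, with an expected range of 12 nM to 100 nM.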

Compound 4, half-maximal inhibitory concentration: 150 nM
For compound 4 the middle estimate is 4.3-fold (0.63 log units) below the measured one; the whole stated range lies below it.
By their numbers in this assay, from the lowest: compound 3; then compounds 2, 4 and 1 (each within the scatter of the next).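

In this assay, the group on the sulfonamide nitrogen clearly affects the result: placing 3-chloro-4-fluorophenyl in place of 4-methylphenyl gives a 4.4-fold higher number from compound 3 to compound 4 (0.64 log units; beyond the scatter). The earlier compounds shown here offered no single change at this position, so this is its first direct reading. Nothing available explains why the number rises.

Going by these compounds, it remains open whether the chlorine, the fluorine or the pair accounts for the step. A phenyl ring carrying only one of these atoms, or a methoxy group, could help separate these possibilities.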